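The source may hold more compounds than are shown below. What is called first, only, known or untested is meant among the compounds shown, and "the series" means these compounds.

In an ADME assay on CHO cells (Cricetulus griseus) for cytotoxicity, read by MTT assay (a higher number here means that more compound is tolerated, a lower number that less compound is tolerated), two compounds have been measured so far. Compound 1 `FC(F)(F)c1cccc(Nc2cc3[nH]c(Nc4ccc(N5CCN(CC6CC6)CC5)cn4)nc3cn2)c1` gives 1700 nM, and compound 2 `Fc1ccc(Nc2cc3[nH]c(Nc4ccc(N5CCNCC5)cn4)nc3cn2)cc1F` gives 33000 nM. Compound 2 therefore holds the higher of the two numbers, by a gap well beyond the usual scatter. Compound 3 `Fc1ccc(Nc2cc3[nH]c(Nc4ccc(N5CCN(CC6CC6)CC5)cn4)nc3cn2)cc1F` differs from compound 2 in one place: cyclopropylmethyl in place of hydrogen on an amine nitrogen in a ring. Going by the values given here, no measured pair shows this change alone. Differing from compound 2 elsewhere as well, compound 1 already carries the 4-(cyclopropylmethyl)piperazin-1-yl group, and compound 1 gives 1700 nM, which points toward a lower number. A clear drop beyond the scatter is therefore expected, with an estimated step of an 8.3-fold lower number from compound 2 to compound 3 (0.92 log units; beyond the scatter). For compound 3 the estimate is 4000 nM, with an expected range of 1200 nM to 14000 nM.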

Compound 3, half-maximal cytotoxic concentration: 1200 nM
For compound 3 the middle estimate is 3.3-fold (0.52 log units) above the measured one, within the range that was stated.
By their numbers in this assay, from the lowest: compounds 3 and 1 (each within the scatter of the next); then compound 2.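

In this assay, the change from piperazin-1-yl to 4-(cyclopropylmethyl)piperazin-1-yl now stands alone and gives a 28-fold lower number from compound 2 to compound 3 (1.44 log units; beyond the scatter), so a change on this one ring nitrogen is enough for a large shift in how much compound the cells tolerate. Putting 3,4-difluorophenyl in place of 3-(trifluoromethyl)phenyl while keeping the cyclopropylmethyl group gives a 1.4-fold lower number from compound 1 to compound 3 (0.15 log units; within the scatter), so this pair shows no readable difference from that swap. Of the three compounds, the two carrying cyclopropylmethyl sit together at the low end, and compound 2, with hydrogen on that nitrogen, stands clearly higher.

As far as these compounds go, whether a methyl group, a longer chain such as butyl, or an acetyl group on the same nitrogen would lower the number as far remains open. Nothing available gives a reason for the drop.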